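Returning to a direct heteroaryl on the carbonyl carbon

The source may report more compounds than this note shows. Statements on the series, on what has been measured and on what is new or still open speak of the compounds shown alone.

Compound 3 `COc1ccc(Cn2c(CCc3ccccc3)nnc2[C@H](NC(=O)CCc2cccnc2)c2c[nH]c3ccccc23)cc1` gives 177 nM in an in vitro assay on LLC-PK1 cells for displacement of a labelled ligand from growth hormone secretagogue receptor type 1 (Homo sapiens) (a higher number here means a weaker inhibitor, a lower number a stronger inhibitor), the highest number among the three measured compounds. Compound 1 `COc1ccc(Cn2c(CCc3ccccc3)nnc2[C@H](NC(=O)c2ccccn2)c2c[nH]c3ccccc23)cc1` gives 0.7 nM and compound 2 `COc1ccc(Cn2c(CCc3ccccc3)nnc2[C@H](NC(=O)Cc2ccccn2)c2c[nH]c3ccccc23)cc1` gives 3 nM in this assay. Compound 4 `COc1ccc(Cn2c(CCc3ccccc3)nnc2[C@H](NC(=O)c2cnccn2)c2c[nH]c3ccccc23)cc1` differs from compound 3 by pyrazin-2-yl in place of 2-(pyridin-3-yl)ethyl on a carbonyl carbon. The step that bears most directly on this change is a 250-fold higher number from compound 1 to compound 3 (2.40 log units; beyond the scatter), which is the same linker change run the other way; the steps of a 4.3-fold higher number from compound 1 to compound 2 (0.63 log units; beyond the scatter) and a 59-fold higher number from compound 2 to compound 3 (1.77 log units; beyond the scatter) show the number rising with each added chain carbon. Compound 4 restores a six-membered aromatic ring directly on the carbonyl carbon as in compound 1, so a large drop in the number is expected. For compound 4 the expected step is an 89-fold lower number from compound 3 to compound 4 (1.95 log units; beyond the scatter), giving an estimated 2 nM with a range of 0.5 nM to 10 nM.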

Compound 4, half-maximal inhibitory concentration: 14 nM
Compound 4: the middle estimate sits 7.0-fold (0.85 log units) below what was measured, outside the stated range (above it).
By their numbers in this assay, from the lowest: compound 1; then compound 2; then compound 4; then compound 3.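

In this assay, a six-membered aromatic ring directly on the carbonyl carbon does not by itself restore the lowest numbers: a 13-fold lower number from compound 3 to compound 4 (1.10 log units; beyond the scatter) recovers part of the loss, but a 20-fold higher number from compound 1 to compound 4 (1.30 log units; beyond the scatter) shows that the identity of the ring also counts at this position. The (pyridin-2-yl)methyl amide also keeps the lower number, with a 4.7-fold higher number from compound 2 to compound 4 (0.67 log units; beyond the scatter), so the direct attachment does not outweigh the ring change here. No measured evidence accounts for the pyrazin-2-yl result. Still open, as far as these compounds go, is how a plain phenyl or a pyridin-3-yl on the carbonyl carbon would read in this assay.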